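The source may hold more compounds than are shown below. What is called first, only, known or untested is meant among the compounds shown, and "the series" means these compounds.

Measured so far:
compound 1, `O=C1c2cc(COc3ccccc3)nn2CCN1c1ccc(F)cn1`, 72%
compound 2, `O=C1c2cc(COc3ccccc3F)nn2CCN1c1ccc(F)cc1`, 66%
compound 3, `O=C1c2cc(COc3cccc(F)c3)nn2CCN1c1ccc(F)cc1`, 70%

In a functional assay on HEK293 cells for positive allosteric modulation of metabotropic glutamate receptor 5 (Homo sapiens), read by calcium flux (a higher number here means a larger maximal response, a lower number a smaller maximal response), compound 3 gives 70%, which places it second among the three numbers. Its nearest neighbour is compound 1, whose value in this assay is 72%, and furthest is compound 2 with 66%; both gaps lie within the scatter, so the three compounds cannot be ordered on these numbers.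

The next compound, compound 4, has the structure `O=C1c2cc(COc3cccc(F)c3)nn2CCN1c1ccc(F)cn1`. It differs from compound 3 in one place: 5-fluoropyridin-2-yl in place of 4-fluorophenyl on an amide-type nitrogen in a ring.

Going by the values given here, the only step measured so far, from compound 2 to compound 3, concerned the fluorine position on the phenoxy group and gave a number 4 percentage points higher from compound 2 to compound 3 (within the scatter). It does not touch the group on the amide-type nitrogen, so it bears on the present change only in showing how little these compounds have moved. Among the compounds with values here, compound 1 already carries the 5-fluoropyridin-2-yl group, and its value sits within the scatter of that of compound 3, though compound 1 also differs in the phenoxy part, so no clean step can be drawn.

Compound 4 is therefore expected to lie near compound 3, with the step from compound 3 to compound 4 estimated at a number 1 percentage points higher from compound 3 to compound 4 (within the scatter), not beyond the scatter. The estimate for compound 4 is 71%, with a range from 60% to 82%.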

Compound 4, largest response reached (Emax), in percent of the reference or control that the assay uses: 62%
Estimate against measurement, compound 4: 9 percentage points above; the range from low to high includes it.
By their numbers in this assay, from the lowest: compounds 4, 2, 3 and 1 (each within the scatter of the next).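

In this assay, going by these compounds alone, the group on the amide-type nitrogen in a ring can now be read directly for the first time: 5-fluoropyridin-2-yl in place of 4-fluorophenyl gives a number 8 percentage points lower from compound 3 to compound 4 (within the scatter), so this exchange, which brings in one hydrogen-bond acceptor by the count, does not separate the two compounds. Within the data shown here, the second new step is the first reading of the phenoxy part with 5-fluoropyridin-2-yl held fixed: fluoro in place of hydrogen on an aromatic carbon gives a number 10 percentage points lower from compound 1 to compound 4 (within the scatter), and so that change does not separate its two compounds either. The data offer no measured basis for explaining either step.

As far as these compounds go, what remains open is whether any group on this nitrogen can move the maximal response beyond the scatter, for example a pyrimidine ring, a cyclohexyl group or a longer chain such as a benzyl group. The same question stands for the phenoxy ring, where a chloro, methoxy or nitrile group would test more than the fluorine and hydrogen seen so far.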